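Adding a Second Chloro Group to the Urea Aryl Ring

The compounds below may be only part of what the source reports. "The series", "measured", "known", "first", "only" and "open" are said of these compounds alone.

Three measured ureas and one unmeasured one are compared. Compound 1 `CN(C)CCNc1nc(-c2ccc(NC(=O)Nc3ccc(Cl)cc3)cc2)nc2ccsc12` gives 95 nM in a functional assay on HT-29 cells (Homo sapiens) for cytotoxicity, read by MTT assay, with a stated time of 72 h; a higher number here means a weaker inhibitor, a lower number a stronger inhibitor. Compound 3 `CN(C)CCNc1nc(-c2ccc(NC(=O)Nc3ccc(Cl)cc3Cl)cc2)nc2ccsc12` differs from it by chloro in place of hydrogen on an aromatic carbon, and in this assay compound 3 gives 1320 nM, so that this change made a 14-fold higher number from compound 1 to compound 3 (1.14 log units; beyond the scatter). Compound 2 `CN(C)CCNc1nc(-c2ccc(NC(=O)Nc3ccccc3Cl)cc2)nc2c(Cl)c(Cl)sc12` has a different core; the difference between the two cores of compound 1 and compound 2 is not broken down here. In this assay compound 2 gives 570 nM, a number standing between those of compound 1 and compound 3.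

Compound 4 `CN(C)CCNc1nc(-c2ccc(NC(=O)Nc3ccc(Cl)cc3Cl)cc2)nc2c(Cl)c(Cl)sc12` has not yet been measured. It differs from compound 2 by chloro in place of hydrogen on an aromatic carbon. Within the data shown here, this is the same kind of change as the one from compound 1 to compound 3, but not the same: in compound 3 the entering chloro sits ortho to a large group and meta to a chloro group, whereas in compound 4 it sits meta to a chloro group and para to a large group. Because the same kind of change earlier gave a 14-fold higher number from compound 1 to compound 3 (1.14 log units; beyond the scatter), the expected step is a 5.1-fold higher number from compound 2 to compound 4 (0.71 log units; beyond the scatter). The place of the entering chloro differs and the comparison rests on one measured pair, so the expected step is taken as smaller than the earlier one. For compound 4 the estimate in this assay is 2900 nM, expected to fall between 900 nM and 9000 nM.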

Compound 4, half-maximal inhibitory concentration: 1280 nM
Compound 4: middle estimate off by 2.3-fold (0.36 log units), on the high side, and the stated range covers the measured number.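

In this assay, chloro in place of hydrogen on the urea aryl ring again goes with a higher number, a 2.2-fold higher number from compound 2 to compound 4 (0.35 log units; beyond the scatter), so in these two pairs the direction of the step is the same on both cores. Among these compounds, the size of the step does not carry over, and a value read from one pair would not have served as the size of the step in the other: the same change on two cores in this assay, a 14-fold higher number (1.14 log units; beyond the scatter) from compound 1 to compound 3 and a 2.2-fold higher number (0.35 log units; beyond the scatter) from compound 2 to compound 4, 6.2-fold (0.79 log units) apart, beyond the scatter of two such steps What this does not show is why the steps differ, since the two pairs differ both in the core and in the place of the entering chloro, which in compound 4 sits meta to a chloro group and para to a large group, and with only one pair on each core neither difference can be separated from the other or made into a rule for the series.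

Open, going by these compounds, is the step from a 2-chlorophenyl urea to a 2,4-dichlorophenyl urea on the core of compound 1, which would set the identical change on both cores. Also open, on these data alone, is whether a bromo or a methoxy group entering at the same place would follow the chloro steps on these two cores.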